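From 3-chlorobenzyl to 4-methylbenzyl: what to expect

The compounds below may be only part of what the source reports. "The series", "measured", "known", "first", "only" and "open" are said of these compounds alone.

Measured in a functional assay on MCF7 cells (Homo sapiens) for inhibition, read by MTT assay, with a stated time of 48 h; on this read-out lower numbers stand for stronger inhibition and higher numbers for weaker inhibition:
compound 1 `COc1ccc(C/N=C2\NC(=O)/C(=C3\CCNC(=O)c4[nH]ccc43)S2)cc1` gives 6240 nM
compound 2 `O=C1N/C(=N\Cc2ccc(Cl)cc2)S/C1=C1/CCNC(=O)c2[nH]ccc21` gives > 100000 nM (a limit, not a number)
compound 3 `O=C1N/C(=N\Cc2cccc(Cl)c2)S/C1=C1/CCNC(=O)c2[nH]ccc21` gives 20700 nM

Of the two actual numbers, compound 3 has the higher one, so it inhibits less strongly than compound 1. Compound 2 gives only a limit. Compound 4 `Cc1ccc(C/N=C2\NC(=O)/C(=C3\CCNC(=O)c4[nH]ccc43)S2)cc1` carries 4-methylphenyl in place of 3-chlorophenyl on a saturated chain carbon bound to a double-bonded nitrogen.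

Swapping 4-methoxyphenyl for 4-chlorophenyl gave a large step: an at least 16-fold higher number from compound 1 to compound 2 (1.20 log units; beyond the scatter). The 3-chlorophenyl group falls in between: a 3.3-fold higher number from compound 1 to compound 3 (0.52 log units; beyond the scatter) and an at least 4.8-fold lower number from compound 2 to compound 3 (0.68 log units; beyond the scatter). These steps point both ways, so only a slight drift to a lower number, within the scatter, is expected in this assay. The expected step is a 1.6-fold lower number from compound 3 to compound 4 (0.20 log units; within the scatter). For compound 4 the estimated value is 13000 nM, with an expected range of 4000 nM to 50000 nM.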

Compound 4, half-maximal inhibitory concentration: 8150 nM
Compound 4: the middle estimate sits 1.6-fold (0.20 log units) above what was measured; measured number inside the range.
By their numbers in this assay, from the lowest: compounds 1 and 4 (each within the scatter of the next); then compound 3. At a limit, above all of these: compound 2.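

Replacing 3-chlorophenyl with 4-methylphenyl gives a 2.5-fold lower number from compound 3 to compound 4 (0.40 log units; beyond the scatter), and methyl in place of chloro gives an at least 12-fold lower number from compound 2 to compound 4 (1.08 log units; beyond the scatter), so among these four compounds the two chloro compounds carry the weaker results. Methyl in place of methoxy gives a 1.3-fold higher number from compound 1 to compound 4 (0.12 log units; within the scatter), so these two groups cannot be told apart here. Compound 2 gives a limit, not a number: the limit of > 100000 nM in this assay, at which 1 of the 4 values shown sits.

Going by these compounds, whether an amine or a carboxylic acid on the aromatic ring would keep inhibition at this level stays open. So does the effect of a longer chain in place of the benzyl link.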